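The compounds below may be only part of what the source reports. "The series", "measured", "known", "first", "only" and "open" are said of these compounds alone.

Working notes on the series. Compound 1 `O=c1[nH]c(=O)n([C@H]2C[C@H](O)[C@@H](CO)O2)cc1C#CI` carries an iodo group on the alkyne that hangs from the shared core. In a functional assay on OST cells (Homo sapiens) for inhibition (a lower number here means a stronger inhibitor, a higher number a weaker inhibitor), compound 1 gives 34000 nM. Compound 2 `CC(=O)OC[C@H]1O[C@@H](n2cc(C#CI)c(=O)[nH]c2=O)[C@@H](OC(C)=O)[C@@H]1OC(C)=O`, the triacetylated analogue, gives 5400 nM in this assay. For the measured compounds named here, of the two measured numbers, compound 1 therefore has the highest, and compound 2 stands lower by a margin beyond the usual scatter; the two structures differ in more than one place, so no single step connects them.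

Compound 3 `C[Si](C)(C)C#Cc1cn([C@H]2C[C@H](O)[C@@H](CO)O2)c(=O)[nH]c1=O` has not yet been measured. Its relation to compound 1 is a group of 4 heavy atoms (3 carbon, 1 silicon; no ring) in place of one iodine atom, on a triple-bonded carbon. Going by the values given here, no measured pair shows a change of this kind, and compound 2 bears no information on this position, so the expectation rests on compound 1 alone. Compound 3 is expected to land at 50000 nM, within a range of 10000 nM to 250000 nM. The expected step of a 1.5-fold higher number from compound 1 to compound 3 (0.17 log units; within the scatter) is thus small, leaning toward a weaker inhibitor, and may well prove to be none beyond the scatter once the measurement is in hand.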

Compound 3, half-maximal inhibitory concentration: 23000 nM
The estimate for compound 3 lay 2.2-fold (0.34 log units) above the measured number; the range from low to high includes it.
By their numbers in this assay, from the lowest: compound 2; then compounds 3 and 1 (each within the scatter of the next).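

For the compounds shown here, this is the first reading at the triple-bonded carbon: in this assay, a group of 4 heavy atoms (3 carbon, 1 silicon; no ring) in place of the iodo group gives a 1.5-fold lower number from compound 1 to compound 3 (0.17 log units; within the scatter). Within these two compounds, then, a group of 4 heavy atoms and a single iodine atom at this carbon cannot be told apart by their numbers, and the exchange does not come near the separation already seen between compound 2 and compound 1, a pair that differs in more than one place and so gives no reading on this position. No accompanying measurement bears on this result, so it stands as a description of the numbers alone.

Going by these compounds, both groups have no ring, no hydrogen-bond donors or acceptors and no net charge, so what an amine, a carboxylic acid or a longer alkyl chain would give on the triple-bonded carbon remains open. Also open, on these data alone, is whether the same exchange would leave the number equally unmoved on the triacetylated scaffold of compound 2, where only the iodo group is on record.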